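Methylsulfonyl with propanoic acid: an unmeasured gap

The source may report more compounds than this note shows. Statements on the series, on what has been measured and on what is new or still open speak of the compounds shown alone.

Compound 3 `CC(C)(C)c1ccc(CN(Cc2cccc(CCC(=O)O)c2)S(=O)(=O)c2ccc(Cl)cc2)cc1` has no numeric result in a functional assay on HEK293 cells for agonist activity at prostaglandin E2 receptor EP2 subtype (Rattus norvegicus), read by cAMP accumulation; on this read-out lower numbers stand for an effect already at smaller amounts and higher numbers for an effect only at larger amounts of compound; for compound 3 the assay reports "not determined" (no result reported), so its standing among the measured members cannot be placed. Compound 4 `CC(C)(C)c1ccc(CN(Cc2cccc(CCC(=O)O)c2)S(C)(=O)=O)cc1` differs from it by methyl in place of 4-chlorophenyl on a sulfonyl sulfur. The neighbours that carry numbers are compound 1 `CC(C)(C)c1ccc(CN(Cc2cccc(OCC(=O)O)c2)S(C)(=O)=O)cc1`, which in this assay gives 203 nM, and compound 2 `CC(C)(C)c1ccc(CN(Cc2cccc(CCC(=O)O)c2)S(=O)(=O)c2nccs2)cc1`, which in this assay gives 1.1 nM. Compound 1 shares the methylsulfonyl of compound 4 but carries a different acid side chain; compound 2 shares the propanoic acid of compound 4 but carries a different group on the sulfonyl sulfur. Among the compounds with values here, no measured pair isolates the step from compound 3 to compound 4, so neither its size nor its direction can be read from the data, and with compound 3 lacking a value the step has no anchor at all. For compound 4 the expected value in this assay is 30 nM, with a range from 5 nM to 200 nM, set by the values of compound 1 203 nM and compound 2 1.1 nM.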

Compound 4, half-maximal effective concentration: 48 nM
Compound 4: the middle estimate sits 1.6-fold (0.20 log units) below what was measured; low and high end bracket the measured number.
By their numbers in this assay, from the lowest: compound 2; then compound 4; then compound 1.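

With the propanoic acid side chain held constant, this assay now shows that the group on the sulfonyl sulfur strongly affects the result: methyl in place of 1,3-thiazol-2-yl gives a 44-fold higher number from compound 2 to compound 4 (1.64 log units; beyond the scatter). With the methylsulfonyl held constant, 2-carboxyethyl in place of carboxymethoxy on an aromatic carbon gives a 4.2-fold lower number from compound 1 to compound 4 (0.63 log units; beyond the scatter), so the acid side chain also matters, though this step is modest and the one at the sulfur large. Nothing available gives a cause for either step.

The step between 4-chlorophenyl and methyl cannot be read, since compound 3 has no number. Open too, going by these compounds, are where a plain phenyl or a longer alkyl chain on the sulfonyl sulfur would fall, and whether carboxymethoxy would cost the same with 1,3-thiazol-2-yl on the sulfur.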